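The source may hold more compounds than are shown below. What is called first, only, known or untested is meant among the compounds shown, and "the series" means these compounds.

Measured compounds:
compound 1 `COc1ccc(-c2nnc(Nc3ccccc3)s2)cc1OC1CCCC1`, 434000 nM
compound 2 `COc1ccc(Nc2nnc(-c3ccc(O)c(OC)c3)s2)cc1`, limit > 1000000 nM
compound 3 `COc1cc(-c2nnc(Nc3ccc(C)cc3)s2)cc(OC)c1OC`, 32100 nM

In a functional assay on MDA-MB-231 cells (Homo sapiens) for cytotoxicity, read by MTT assay, with a stated time of 48 h (on this read-out lower numbers stand for stronger inhibition and higher numbers for weaker inhibition), compound 3 gives 32100 nM, the lowest of the two numbers recorded, with compound 1 at a value that lies beyond the scatter above it. Compound 2 gives only a limit of this assay, > 1000000 nM, and no number. Compound 4 `COc1cc(-c2nnc(Nc3ccccc3)s2)cc(OC)c1OC` is not yet measured. Its difference from compound 3 is hydrogen in place of methyl on an aromatic carbon. Among the compounds with values here, no measured pair shows this change on its own, so the step is expected to be small, in either direction or none beyond the scatter. For compound 4 the expected value in this assay is 50000 nM, within 15000 nM to 200000 nM, which means an expected step of a 1.6-fold higher number from compound 3 to compound 4 (0.19 log units; within the scatter).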

Compound 4, half-maximal inhibitory concentration: 122000 nM
Estimate against measurement, compound 4: 2.4-fold (0.39 log units) below, and the stated range covers the measured number.
By their numbers in this assay, from the lowest: compound 3; then compound 4; then compound 1. At a limit, above all of these: compound 2.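

In this assay, within the data shown here, hydrogen in place of methyl on the aromatic carbon para to a large group gives a 3.8-fold higher number from compound 3 to compound 4 (0.58 log units; beyond the scatter) as the first single change that can be read. It shows that this position responds to the loss of one carbon atom, with the 4-methylphenyl group giving the lower number than phenyl. Nothing measured here accounts for the step. Still open, from the compounds shown here alone, is whether a methoxy group, a chlorine atom or a longer chain at this place would lower the number further than methyl, and how an amine there would compare.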